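Changing the Aryl Group: From Compound 1 to Compound 4

A few compounds are considered here, and "the series" means these few. Any claim that something is new, unique, unknown or untested is made for them only; others in the source may bear on it.

Compound 1 `Cc1ccc(-c2nnc(COc3cnn(C(C)(C)C)c(=O)c3Cl)o2)cc1` was tested in a functional assay on the whole organism for inhibition, with Mythimna separata as the target, with a stated time of 5 days (a lower number here means that less compound is needed, a higher number that more compound is needed for the effect), where compound 1 gives 19.9 ug/mL. Compound 2 `CC(C)(C)n1ncc(OCc2nnc(-c3cc(F)c(Cl)cc3Cl)s2)c(Cl)c1=O` gives 67.1 ug/mL in this assay, a higher number than compound 1, and this gap lies beyond the usual scatter. Compound 3 `CC(C)(C)n1ncc(OCc2nnc(-c3cc(F)c(Cl)c([N+](=O)[O-])c3Cl)o2)c(Cl)c1=O` reaches only a limit of the assay, > 300 ug/mL, so no number is known for it; one value sits at the limit of > 300 ug/mL in this assay, at which 1 of the 3 values shown sits. Of the two numbers shown, compound 1 has the lowest. Compound 4 `CC(C)(C)n1ncc(OCc2nnc(-c3c(F)cccc3F)o2)c(Cl)c1=O` has not been measured; it differs from compound 1 by 2,6-difluorophenyl in place of 4-methylphenyl on an aromatic carbon. For the measured compounds named here, no measured pair shows this exact change. Since the other halogen-bearing aryl compounds, compound 2 and compound 3, give a higher number or a limit, the step from compound 1 to compound 4 is expected to be a 2.3-fold higher number from compound 1 to compound 4 (0.35 log units; beyond the scatter). Compound 4 is estimated at 45 ug/mL, within 12 ug/mL to 180 ug/mL.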

Compound 4, half-maximal effective concentration: 45.4 ug/mL
Compound 4: middle estimate off by 1.0-fold (0.00 log units), on the low side, within the range that was stated.
By their numbers in this assay, from the lowest: compound 1; then compounds 4 and 2 (each within the scatter of the next). At a limit, above all of these: compound 3.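

For the compounds shown here, the new result gives the first pair here that differs in one place only, so the aryl group on the five-membered ring can be read on its own. Replacing 4-methylphenyl with 2,6-difluorophenyl gives a 2.3-fold higher number from compound 1 to compound 4 (0.36 log units; beyond the scatter) in this assay and shows that this position responds to the choice of aryl group, though the step is modest. Nothing measured here explains that step.

Going by these compounds, only these two aryl groups can be compared directly, so it stays open whether a plain phenyl, a methoxyphenyl or an amine at this position would give a lower or a higher number. On these data alone, it is also open whether a single fluorine would give the same step as two.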